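Stability notes: from compound 2 to compound 3

A few compounds are considered here, and "the series" means these few. Any claim that something is new, unique, unknown or untested is made for them only; others in the source may bear on it.

Measured compounds:
- compound 1 `CCCCCCCCCc1ccc(OP(=O)(O)OC[C@H]2O[C@@H](n3cc(F)c(=O)[nH]c3=O)C[C@@H]2OC(=O)c2ccccc2)cc1` gives > 120 h (a limit of the assay)
- compound 2 `C[n+]1cccc(OP(=O)([O-])OC[C@H]2O[C@@H](n3cc(F)c(=O)[nH]c3=O)C[C@@H]2OC(=O)c2ccccc2)c1` gives 14.8 h (a number)

Both entries come from a physicochemical assay for metabolic stability, read by HPLC, tested at 2 mM (on this read-out higher numbers stand for a longer-lived compound and lower numbers for a shorter-lived compound), and no other read-out is at hand. The entry for compound 1 is a limit and not a number. For the measured compounds named here, compound 2 gives the only actual number so far, 14.8 h in this set, and so it is the sole numerical anchor.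

Compound 3 `CCOC(=O)C[n+]1cccc(OP(=O)([O-])OC[C@H]2O[C@@H](n3cc(F)c(=O)[nH]c3=O)C[C@@H]2OC(=O)c2ccccc2)c1` differs from compound 2 in one place: ethoxycarbonyl in place of hydrogen on a saturated chain carbon bound to an aromatic nitrogen with ethoxycarbonyl in place of hydrogen on a saturated chain carbon bound to an aromatic nitrogen. Cut one bond further out, methyl becomes (ethoxycarbonyl)methyl.

Going by the values given here, no measured pair covers this change, so any expectation in this assay is a loose judgement. A shift towards a shorter life, beyond the usual scatter, is expected, although no change remains inside the range. The estimated step is a 2.5-fold lower number from compound 2 to compound 3 (0.39 log units; beyond the scatter) in that direction. For compound 3 the expected half-life is 6 h with an estimated range of 1.5 h to 16 h in this assay.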

Compound 3, half-life: 1.1 h
The estimate for compound 3 lay 5.5-fold (0.74 log units) above the measured number; the whole stated range lies above it.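

In this assay, the saturated chain carbon bound to an aromatic nitrogen proves to be a sensitive place in this series: turning methyl into (ethoxycarbonyl)methyl there gives a 13-fold lower number from compound 2 to compound 3 (1.13 log units; beyond the scatter) and leaves the rest of the structure untouched. For the compounds shown here, this is the first comparison in the set that differs in one place, and it shows that a single substituent on that carbon can by itself shift the half-life well beyond the usual scatter, with ethoxycarbonyl on the shorter-lived side. The data shown offer no measured reason for the drop.

From the compounds shown here alone, whether the shift follows the ethoxycarbonyl group as a whole or simply the longer substituent stays open, and a plain propyl chain, a carboxylic acid or an amide on the same carbon would separate these readings in this assay on the same footing. Compound 1 gives > 120 h as a limit and not a number, and it differs from compound 2 in more than one place, so it adds nothing to the reading of this position.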